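The source may hold more compounds than are shown below. What is called first, only, known or untested is meant among the compounds shown, and "the series" means these compounds.

Working notes on the series. Compound 1 `O=c1cc(-c2ccccc2)oc2cc(OCCCCNc3nc4ccccc4s3)cc(O)c12` gives 14.6 ug/mL in a functional assay on Ca-Ski cells (Homo sapiens) for cytotoxicity, read by sulforhodamine B assay, with a stated time of 48 h; on this read-out higher numbers stand for weaker inhibition and lower numbers for stronger inhibition. Compound 2 `O=c1cc(-c2ccccc2)oc2cc(OCCCCNc3nc4ccc([N+](=O)[O-])cc4s3)cc(O)c12` gives 13.2 ug/mL in this assay, and compound 3 `O=c1cc(-c2ccccc2)oc2cc(OCCCCNc3nc4ccc(Cl)cc4s3)cc(O)c12` gives 12.4 ug/mL in this assay. The steps among them are a 1.1-fold lower number from compound 1 to compound 2 (0.04 log units; within the scatter), a 1.2-fold lower number from compound 1 to compound 3 (0.07 log units; within the scatter) and a 1.1-fold lower number from compound 2 to compound 3 (0.03 log units; within the scatter); none of these lies beyond the scatter, so hydrogen, nitro and chloro at this aromatic carbon cannot be told apart on these data. Compound 3 carries the lowest of the three numbers, with compound 2 nearest and compound 1 furthest, both gaps within the scatter.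

Compound 4 `O=c1cc(-c2ccccc2)oc2cc(OCCCCNc3nc4ccc(Br)cc4s3)cc(O)c12` is not yet measured. It differs from compound 3 by bromo in place of chloro on an aromatic carbon. Within the data shown here, the steps that bear on this change are the earlier substitutions at the same aromatic carbon, chiefly a 1.2-fold lower number from compound 1 to compound 3 (0.07 log units; within the scatter) and a 1.1-fold lower number from compound 2 to compound 3 (0.03 log units; within the scatter), both within the scatter. Compound 4 is therefore expected to show no step beyond the scatter in this assay, an expected step of a 1.1-fold lower number from compound 3 to compound 4 (0.03 log units; within the scatter). The estimate for compound 4 is 11.5 ug/mL, with an expected range from 6 ug/mL to 23 ug/mL.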

Compound 4, half-maximal inhibitory concentration: 12.4 ug/mL
Beside the measured number, compound 4's estimate is 1.1-fold (0.03 log units) below it; measured number inside the range.
By their numbers in this assay, from the lowest: compounds 3, 4, 2 and 1 (each within the scatter of the next).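

Bromo in place of chloro gives no change at the digits printed from compound 3 to compound 4 (within the scatter) in this assay, and the comparisons with the other groups read a 1.1-fold lower number from compound 2 to compound 4 (0.03 log units; within the scatter) and a 1.2-fold lower number from compound 1 to compound 4 (0.07 log units; within the scatter) on the same carbon. Bromo therefore joins hydrogen, nitro and chloro on this aromatic carbon, and the halogen swap in particular adds a direct comparison of two halogens that the earlier compounds did not offer, again without a step beyond the scatter. No measurement at hand explains this flat result.

From the compounds shown here alone, it remains open whether an amine or a carboxylic acid on this aromatic carbon would give a step beyond the scatter. Also open, going by these compounds, is whether a longer chain joining the shared core to the (6-bromo-1,3-benzothiazol-2-yl)amino group would do so.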